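This account rests on a few compounds, and the source may have more. Where it says the series, first, only, none or still open, it means among the compounds named here.

Measured so far in a functional assay on MKN-45 cells (Homo sapiens) for cytotoxicity, read by MTT assay, with a stated time of 72 h; a lower number here means a stronger inhibitor, a higher number a weaker inhibitor:

Compound 1, `COc1ccc(OC)c(/C=N/NC(=O)Nc2ccc(Oc3ccnc(-c4nncn4CCN(C)C)c3)c(F)c2)c1`: 1510 nM
Compound 2, `CN(C)CCn1cnnc1-c1cc(Oc2ccc(NC(=O)N/N=C/c3cccc(Cl)c3Cl)cc2F)ccn1`: 51 nM
Compound 3, `Cc1cc(/C=N/NC(=O)Nc2ccc(Oc3ccnc(-c4nncn4CCN(C)C)c3)c(F)c2)cc(C)c1O`: 1510 nM

Compound 1 stands level with compound 3 at the digits reported, the two of them giving the highest numbers of the three; compound 2 is the furthest away from compound 1, with a 30-fold lower number from compound 1 to compound 2 (1.47 log units; beyond the scatter). The other steps are no change at the digits printed from compound 1 to compound 3 (within the scatter) and a 30-fold higher number from compound 2 to compound 3 (1.47 log units; beyond the scatter).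

Compound 4, `CN(C)CCn1cnnc1-c1cc(Oc2ccc(NC(=O)N/N=C/c3ccc(F)cc3F)cc2F)ccn1`, has not been measured. It differs from compound 1 in one place: 2,4-difluorophenyl in place of 2,5-dimethoxyphenyl on a carbon with a double bond to nitrogen.

For the measured compounds named here, two measured steps bear on this. The exchange of 2,5-dimethoxyphenyl for a halogenated ring, 2,3-dichlorophenyl, gave a 30-fold lower number from compound 1 to compound 2 (1.47 log units; beyond the scatter), a large step to a lower number. The exchange for 4-hydroxy-3,5-dimethylphenyl gave no change at the digits printed from compound 1 to compound 3 (within the scatter). Compound 4 carries a halogenated ring, 2,4-difluorophenyl, which places it nearer the compound 2 case than the compound 3 case, though with fluorine in place of chlorine and a different substitution pattern the step to compound 2 need not be matched in full. A step to a lower number, beyond the scatter, is therefore expected: a 7.6-fold lower number from compound 1 to compound 4 (0.88 log units; beyond the scatter).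

Compound 4 is estimated at 200 nM, with a range from 50 nM to 800 nM.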

Compound 4, half-maximal inhibitory concentration: 810 nM
For compound 4 the middle estimate is 4.1-fold (0.61 log units) below the measured one; the whole stated range lies below it.
By their numbers in this assay, from the lowest: compound 2; then compounds 4, 1 and 3 (each within the scatter of the next).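

In this assay a halogenated ring on this carbon with a double bond to nitrogen is not enough on its own for a low number: 2,4-difluorophenyl gives a 1.9-fold lower number from compound 1 to compound 4 (0.27 log units; within the scatter) and also a 1.9-fold lower number from compound 3 to compound 4 (0.27 log units; within the scatter) so compound 4 cannot be told apart from compounds 1 and 3. The two halogenated rings themselves stand far apart, with a 16-fold higher number from compound 2 to compound 4 (1.20 log units; beyond the scatter) on going from 2,3-dichlorophenyl to 2,4-difluorophenyl, so the low number belongs to compound 2 alone among the four and not to halogenated rings as a class, with compound 4 the case against such a pattern. No measurement at hand accounts for the gap between these two halogenated rings.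

Still open, on these data alone, is whether the low number of compound 2 follows the chlorine atoms or their arrangement on the ring, a question that a 2,4-dichlorophenyl or a 2,3-difluorophenyl ring at this position would separate. Also open, as far as these compounds go, is how this position responds to a ring carrying an amine or a carboxylic acid.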